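Moving a Fluorine Around the Phenyl Ring

The source may hold more compounds than are shown below. What is called first, only, known or untested is meant among the compounds shown, and "the series" means these compounds.

Of the compounds shown here, three built on one shared core have been tested in a functional assay on the whole organism (strain Swiss) with Mus musculus as the target, in the maximal electroshock model, with a stated time of 1 h, at a dose of 100 mg/kg by the intraperitoneal route; on this read-out lower numbers stand for a weaker effect and higher numbers for a stronger effect at the one dose given. Compound 1 `CCC(C(=O)N1CCN(c2cccc(F)c2)CC1)N1C(=O)CCC1=O` gives 0%. Compound 2 `CC(C(=O)N1CCN(c2ccccc2F)CC1)N1C(=O)CCC1=O` gives 0%, and compound 3 `CC(C(=O)N1CCN(c2ccc(F)cc2)CC1)N1C(=O)CCC1=O` gives 0%. Compound 3 thus stands level with compounds 1 and 2 at the digits shown; none of the three protects the animals at this dose, and the step of no change at the digits printed from compound 2 to compound 3 (within the scatter) shows that carrying the fluorine to another place on the phenyl ring left the read-out exactly where it was.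

Compound 4 `CC(C(=O)N1CCN(c2cccc(F)c2)CC1)N1C(=O)CCC1=O` is the next candidate. It differs from compound 3 in one way only: 3-fluorophenyl in place of 4-fluorophenyl on an amine nitrogen in a ring. For the measured compounds named here, the single measured step that bears on such a change is no change at the digits printed from compound 2 to compound 3 (within the scatter), and that step stayed within the scatter. Compound 1 already carries the 3-fluorophenyl group that enters here, differing from compound 4 elsewhere in the core, and compound 1 gives 0% as well. Nothing in these results points to a shift beyond the scatter, so the step of no change at the digits printed from compound 3 to compound 4 (within the scatter) is expected to be flat. Compound 4 is therefore estimated at 0%, with a likely range from 0% to 10%.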

Compound 4, a percentage reported as activity, at one dose (the size of the read-out at that dose, not a potency): 0%
Compound 4: middle estimate and measured number agree at the digits printed, within the range that was stated.
By their numbers in this assay, from the lowest: compounds 1, 2, 3 and 4 (each within the scatter of the next).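

With compound 4, the 2-fluorophenyl, 3-fluorophenyl and 4-fluorophenyl groups have all been tested on the same core in this assay, and the results show no change at the digits printed from compound 3 to compound 4 (within the scatter) and no change at the digits printed from compound 2 to compound 4 (within the scatter), so no placement of the fluorine on this phenyl ring stands apart from the others. The change on the chain also leaves the read-out flat: replacing methyl with hydrogen on a saturated chain carbon, two bonds along the chain from an amide-type nitrogen in a ring and a carbonyl carbon, gives no change at the digits printed from compound 1 to compound 4 (within the scatter), which extends the result from the phenyl ring to a second place in the molecule. However, a series in which no compound shows any protection at this dose cannot reveal which of these groups is better, since all of them sit at the bottom of the scale.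

Going by these compounds, it remains open whether a chlorine or methoxy group on the phenyl ring, or a longer chain at the saturated carbon, would lift the read-out above this level. No measurement shown here offers an explanation for the absence of activity in these compounds.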